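This account rests on a few compounds, and the source may have more. Where it says the series, first, only, none or still open, it means among the compounds named here.

Values in a functional assay on Caco-2 cells (Homo sapiens), read by MTT assay, with a stated time of 48 h (a lower number here means a stronger inhibitor, a higher number a weaker inhibitor), are:
Compound 1 `CCn1c(C(=O)NCCCN(C)C)ccc1C(CC)(CC)c1ccc(OCC(=O)C(C)(C)C)c(C)c1` gives 1400 nM
Compound 2 `CCN(CC)CCCNC(=O)c1ccc(C(CC)(CC)c2ccc(OCC(=O)C(C)(C)C)c(C)c2)n1CC` gives 1000 nM
Compound 3 `CCOC(=O)CN(C)C(=O)c1ccc(C(CC)(CC)c2ccc(OCC(O)C(C)(C)C)c(C)c2)n1CC` gives 12200 nM

Compound 3 has the highest number of the three, and its gaps to compound 1 and compound 2 both lie beyond the scatter. Compound 4 `C#CCNC(=O)c1ccc(C(CC)(CC)c2ccc(OCC(O)C(C)(C)C)c(C)c2)n1CC` alters compound 3 in one place, on a carbonyl carbon: propargylamino in place of ((ethoxycarbonyl)methyl)(methyl)amino on a carbonyl carbon. Among the measured compounds shown here, the only measured step, a 1.4-fold lower number from compound 1 to compound 2 (0.15 log units; within the scatter), involves a different change and lies within the scatter, so it gives no guide to size or direction here. With nothing measured that bears on this change, the estimate is a 1.2-fold lower number from compound 3 to compound 4 (0.09 log units; within the scatter), which means no expected shift beyond the scatter. For compound 4 the estimated value is 10000 nM, with an expected range from 3000 nM to 30000 nM.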

Compound 4, half-maximal inhibitory concentration: 39100 nM
Compound 4: middle estimate off by 3.9-fold (0.59 log units), on the low side, outside the stated range (above it).
By their numbers in this assay, from the lowest: compounds 2 and 1 (each within the scatter of the next); then compound 3; then compound 4.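

At this position on a carbonyl carbon, the attached group does affect the result: in this assay, propargylamino in place of ((ethoxycarbonyl)methyl)(methyl)amino gives a 3.2-fold higher number from compound 3 to compound 4 (0.51 log units; beyond the scatter), a modest loss of strength. The entering group is smaller, has a hydrogen-bond donor, and lacks the ester, so several features change together. Nothing available shows which of these differences matters.

From the compounds shown here alone, it remains open how a plain propylamino group, without the triple bond, or a carboxylic acid in place of the ester would behave at this position.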